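The source may hold more compounds than are shown below. What is called first, only, known or untested is meant among the compounds shown, and "the series" means these compounds.

Measured in a functional assay on NIH3T3 cells (Mus musculus); a lower number here means that less compound is needed, a higher number that more compound is needed for the effect:

- Compound 1 `Cn1cncc1C(OCc1ccc(C#N)cc1C#Cc1ccc(C#N)cc1)c1ccc(C#N)cc1`: 11.6 nM
- Compound 2 `Cn1cncc1C(OCc1ccc(C#N)cc1/C=C/c1ccccn1)c1ccc(C#N)cc1`: 23.1 nM
- Compound 3 `Cn1cncc1C(OCc1ccc(C#N)cc1C#Cc1ccc(-c2ccccc2)cc1)c1ccc(C#N)cc1`: > 0.1 nM, a limit and not a number

Within the data shown here, compound 1 holds one of only two true numbers in this small set, and the comparison with the other gives no ranking: a 2.0-fold higher number from compound 1 to compound 2 (0.30 log units; within the scatter). Where compound 1 stands against compound 3 cannot be said, since that value is only a limit.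

The compound still to be measured is compound 4 `CCCCCCC#Cc1cc(C#N)ccc1COC(c1ccc(C#N)cc1)c1cncn1C`. Its difference from compound 1 is hexyl in place of 4-cyanophenyl on a triple-bonded carbon. Seen one bond further out, 2-(4-cyanophenyl)ethynyl gives way to oct-1-yn-1-yl.

Two measured steps offer some guidance. The more relevant one also replaces the 2-(4-cyanophenyl)ethynyl group, and it stayed small: a 2.0-fold higher number from compound 1 to compound 2 (0.30 log units; within the scatter). The other, a step that the limit leaves unreadable from compound 1 to compound 3, changes the same ring but ends at the limit of > 0.1 nM in this assay, at which 1 of the 3 values shown sits, so it gives no size. Neither step replaces a ring with an open chain, so this forecast is uncertain.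

On the strength of the first step alone, no change beyond the scatter is expected in this assay, and the expected step is a 1.7-fold higher number from compound 1 to compound 4 (0.24 log units; within the scatter). For compound 4 the estimated value is 20 nM. The expected range for compound 4 runs from 5 nM to 80 nM.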

Compound 4, half-maximal effective concentration: > 0.1 nM
Compound 4: a limit, no number; the forecaster's own chance of this, stated with the estimate: 10%; the middle value does not contradict the limit.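

In this assay compound 4 gives > 0.1 nM, a limit and not a number. No step from compound 1, compound 2 or compound 3 to compound 4 can therefore be read: the limit of > 0.1 nM in this assay, at which 2 of the 4 values shown sit.

The compounds shown leave open whether hexyl in place of 4-cyanophenyl changes the number at all, and by how much.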